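This account rests on a few compounds, and the source may have more. Where it says the series, first, only, none or still open, it means among the compounds named here.

Compound 1 `O=C(O)c1cc(N2C(=O)C3=C(CCCC3)C2=O)c(F)cc1Cl` gives 3160 nM in a functional assay on the whole organism with Scenedesmus acutus as the target, with a stated time of 20 h (a higher number here means a weaker inhibitor, a lower number a stronger inhibitor), the lowest of the three numbers in hand. Among the compounds with values here, compound 3 `CCC(C)OC(=O)c1cc(N2C(=O)C3=C(CCCC3)C2=O)ccc1Cl` gives 9770 nM and compound 2 `CC(C)COC(=O)c1cc(N2C(=O)C3=C(CCCC3)C2=O)ccc1Cl` gives 15500 nM; both differ from compound 1 in more than one place, so no single-change step links them to it. Within the data shown here, the only single step measured, a 1.6-fold lower number from compound 2 to compound 3 (0.20 log units; within the scatter), concerns sec-butyl in place of isobutyl on an oxygen next to a carbonyl group and says nothing about the change to compound 4 `C#CCOc1cc(N2C(=O)C3=C(CCCC3)C2=O)c(F)cc1Cl`, which is propargyloxy in place of carboxy on an aromatic carbon. Among the measured compounds shown here, no measured step therefore bears on this change, and the expectation rests on compound 1 alone: a step of a 2.1-fold lower number from compound 1 to compound 4 (0.32 log units; beyond the scatter) is estimated, in either direction, with compound 4 expected at 1500 nM within 300 nM to 8000 nM.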

Compound 4, half-maximal inhibitory concentration: 141 nM
Estimate against measurement, compound 4: 11-fold (1.03 log units) above, outside the stated range (below it).
By their numbers in this assay, from the lowest: compound 4; then compound 1; then compounds 3 and 2 (each within the scatter of the next).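

In this assay, propargyloxy in place of carboxy on this aromatic carbon gives a 22-fold lower number from compound 1 to compound 4 (1.35 log units; beyond the scatter) and so shows that the carboxy group, with its hydrogen-bond donor, is not needed here. Within the data shown here, the only earlier step, a 1.6-fold lower number from compound 2 to compound 3 (0.20 log units; within the scatter), altered just the chain of an ester and stayed within the scatter, whereas this change shows that the group at this place can move the number well beyond it. No available evidence accounts for the size of this step. As far as these compounds go, whether the triple bond or the ether oxygen carries the step stays open, and a propoxy or allyloxy group on this carbon would separate the two. From the compounds shown here alone, whether the step holds without the fluoro group also remains open.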